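Swapping the Aromatic Ring on the Chain

This account rests on a few compounds, and the source may have more. Where it says the series, first, only, none or still open, it means among the compounds named here.

Among the measured compounds shown here, in an assay for inhibition of Catechol O-methyltransferase (Rattus norvegicus), read by fluorescence and spectrophotometry (a lower number here means a stronger inhibitor, a higher number a weaker inhibitor), compound 2 `O=C(/C=C/c1ccco1)c1cc(O)c(O)c([N+](=O)[O-])c1` gives 230 nM, one of only two numbers so far; the other belongs to compound 1 `O=C(/C=C/c1cccs1)c1cc(O)c(O)c([N+](=O)[O-])c1`, which gives 190 nM, and the two sit within the scatter of each other. That one measured step, a 1.2-fold higher number from compound 1 to compound 2 (0.08 log units; within the scatter), exchanged one five-membered aromatic ring for another. Compound 3 `Cn1cc(/C=C/C(=O)c2cc(O)c(O)c([N+](=O)[O-])c2)cn1` brings the next change: 1-methyl-1H-pyrazol-4-yl in place of furan-2-yl on a double-bonded chain carbon bound to a double-bonded chain carbon. Because the earlier ring exchange produced a 1.2-fold higher number from compound 1 to compound 2 (0.08 log units; within the scatter), this further swap in the same place is expected to shift this assay little, if at all, beyond the scatter. Compound 3 is therefore estimated at 300 nM, within 120 nM to 800 nM, which means a 1.3-fold higher number from compound 2 to compound 3 (0.12 log units; within the scatter).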

Compound 3, half-maximal inhibitory concentration: 290 nM
Compound 3: the middle estimate sits 1.0-fold (0.01 log units) above what was measured, and the stated range covers the measured number.
By their numbers in this assay, from the lowest: compounds 1, 2 and 3 (each within the scatter of the next).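

In this assay the step to 1-methyl-1H-pyrazol-4-yl from furan-2-yl (a 1.3-fold higher number from compound 2 to compound 3 (0.10 log units; within the scatter)) and the step to it from thiophen-2-yl (a 1.5-fold higher number from compound 1 to compound 3 (0.18 log units; within the scatter)) both stay within the scatter. On a double-bonded chain carbon bound to a double-bonded chain carbon, a five-membered aromatic ring with 2 hetero atoms and a methyl group therefore reads the same as the rings with 1 hetero atom. No supporting data explain why these three rings read alike. Going by these compounds, whether a phenyl ring or a ring carrying an amine would also read the same at this place remains open.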